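Replacing the acetyl group of compound 3

The compounds below may be only part of what the source reports. "The series", "measured", "known", "first", "only" and "open" are said of these compounds alone.

In a functional assay on HCT-116 cells (Homo sapiens) for antiproliferative activity (a lower number here means a stronger inhibitor, a higher number a weaker inhibitor), three compounds sharing one core have been measured. Compound 1 (`Cc1c2c(n3c1CCCN[C@@H](C)[C@H](C)Nc1cc-3ccc1C(N)=O)CC(C)(C)CC2=O`) gives 29 nM, and compound 2 (`Cc1c2c(n3c1CCCN(C)[C@@H](C)[C@H](C)Nc1cc-3ccc1C(N)=O)CC(C)(C)CC2=O`) gives 51 nM. Compound 3 (`CC(=O)N1CCc2c(C)c3c(n2-c2ccc(C(N)=O)c(c2)N[C@@H](C)[C@H](C)C1)CC(C)(C)CC3=O`) gives 24 nM, a number within the scatter of compound 1 and beyond the scatter of compound 2.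

Compound 4 (`Cc1c2c(n3c1CCN(C(=O)C(C)(C)N)C[C@@H](C)[C@H](C)Nc1cc-3ccc1C(N)=O)CC(C)(C)CC2=O`) departs from compound 3 at one place, on a carbonyl carbon whose other neighbours are an amide-type nitrogen in a ring: 1-amino-1-methylethyl in place of methyl on a carbonyl carbon. In words, 1-amino-1-methylethyl stands in place of methyl. Within the data shown here, compound 2 supplies the only measured step, a 1.8-fold higher number from compound 1 to compound 2 (0.25 log units; within the scatter), for a different change, methyl in place of hydrogen on an amine nitrogen in a ring. Among the measured compounds shown here, that step is therefore weak guidance, and no measured compound carries the new group. The data fix no direction, so no shift beyond the scatter is expected. The expected step is a 1.3-fold higher number from compound 3 to compound 4 (0.10 log units; within the scatter). Compound 4 is estimated at 30 nM, with an expected range from 10 nM to 90 nM.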

Compound 4, half-maximal inhibitory concentration: 25 nM
For compound 4 the middle estimate is 1.2-fold (0.08 log units) above the measured one; the measured number falls inside the stated range.
By their numbers in this assay, from the lowest: compounds 3, 4, 1 and 2 (each within the scatter of the next, the first and the last beyond it).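

In this assay putting 1-amino-1-methylethyl in place of methyl on the carbonyl carbon gives a 1.0-fold higher number from compound 3 to compound 4 (0.02 log units; within the scatter) and so leaves the number within the scatter. The earlier compounds shown here held no step at this place, and this one shows that a group bringing a nitrogen, a hydrogen-bond donor and a hydrogen-bond acceptor can stand here without a shift beyond the scatter. Nothing in the data at hand explains this outcome.

The compounds shown leave open whether the amino group of the new substituent contributes anything, as a comparison with a hydroxyl or dimethylamino group in its place could show. They also leave open how a carboxylic acid, a longer amine-bearing chain or a phenyl group would read on this carbonyl carbon.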